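Swapping the aryl substituent on an oxadiazole amidoxime

The source may report more compounds than this note shows. Statements on the series, on what has been measured and on what is new or still open speak of the compounds shown alone.

Two close relatives share one core and differ only in the aromatic ring attached to the amine nitrogen. Compound 1 `NS(=O)(=O)CC(=O)NCCSc1nonc1/C(=N/O)Nc1cccc(C(F)F)c1` carries a difluoromethyl group there; in an assay for inhibition of Indoleamine 2,3-dioxygenase 1 (Homo sapiens), read by fluorescence, with a stated time of 1 h (on this read-out lower numbers stand for stronger inhibition and higher numbers for weaker inhibition), compound 1 gives 130 nM. Compound 2 `NS(=O)(=O)CC(=O)NCCSc1nonc1/C(=N/O)Nc1cccc(Cl)c1` carries a chlorine instead, and in this assay compound 2 gives 21 nM, the lower of the two numbers, so compound 2 is the stronger inhibitor of the pair. Among the measured compounds shown here, the single step between them, a 6.2-fold lower number from compound 1 to compound 2 (0.79 log units; beyond the scatter), is the only measured comparison available.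

Compound 3 `NS(=O)(=O)CC(=O)NCCSc1nonc1/C(=N/O)Nc1ccc(F)c(C(F)F)c1` is not yet measured. Its change from compound 2 is 3-(difluoromethyl)-4-fluorophenyl in place of 3-chlorophenyl on an amine nitrogen. For the measured compounds named here, this largely reverses the earlier step, bringing the difluoromethyl group back, while a fluorine is added as well; no measured pair speaks to that added fluorine. Resting on the reversal, compound 3 is expected to give a weaker number than compound 2, with an expected step of a 5.2-fold higher number from compound 2 to compound 3 (0.72 log units; beyond the scatter). The estimate for compound 3 is therefore 110 nM, with a range from 40 nM to 350 nM.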

Compound 3, half-maximal inhibitory concentration: 73 nM
Beside the measured number, compound 3's estimate is 1.5-fold (0.18 log units) above it, and the stated range covers the measured number.
By their numbers in this assay, from the lowest: compound 2; then compounds 3 and 1 (each within the scatter of the next).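

In this assay, the 3-chlorophenyl group of compound 2 stays ahead of the 3-(difluoromethyl)-4-fluorophenyl group, with a 3.5-fold higher number from compound 2 to compound 3 (0.54 log units; beyond the scatter) at this amine nitrogen. So the lead of the chlorine-bearing ring over a difluoromethyl-bearing ring holds even when the latter also carries a fluorine. Placing fluoro in place of hydrogen on an aromatic carbon gives a 1.8-fold lower number from compound 1 to compound 3 (0.25 log units; within the scatter), which means that this added fluorine cannot be told apart from no change in this assay and that the two difluoromethyl compounds sit together on its scale.

No measurement shown explains why the chlorine-bearing ring gives the lower number. On these data alone, it also remains open whether a trifluoromethyl group or a bromine in place of the chlorine would keep this order, and whether a fluorine added to the 3-chlorophenyl ring of compound 2 would leave its number as unmoved as the added fluorine left the difluoromethyl pair.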